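The compounds below may be only part of what the source reports. "The series", "measured", "known", "first", "only" and "open" are said of these compounds alone.

Compound 1, `O=c1cc(NCc2ccccc2)sc2c([N+](=O)[O-])cc(C(F)(F)F)cc12`, in an ADME assay on Vero cells (Chlorocebus sabaeus) for cytotoxicity, read by MTT assay, with a stated time of 48 h (on this read-out lower numbers stand for stronger inhibition and higher numbers for weaker inhibition), gives > 64 ug/mL.
Compound 2, `O=c1cc(NCc2cccc(F)c2)sc2c([N+](=O)[O-])cc(C(F)(F)F)cc12`, gives > 64 ug/mL.
Compound 3, `O=c1cc(Nc2ccccc2)sc2c([N+](=O)[O-])cc(C(F)(F)F)cc12`, gives > 64 ug/mL.

Each of these three values is a limit of the assay, not a number: the cells were not harmed at the highest concentration tested. Among the measured compounds shown here, compound 3 thus stands at the ceiling of what was tested, and so do the other two, which is the one piece of evidence available, (the limit of > 64 ug/mL in this assay, at which 3 of the 3 values shown sit). The three measured steps are all unreadable for this reason: a step that the two limits leave unreadable from compound 1 to compound 2, a step that the two limits leave unreadable from compound 1 to compound 3 and a step that the two limits leave unreadable from compound 2 to compound 3.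

Compound 4, `O=c1cc(NCC2CCCCC2)sc2c([N+](=O)[O-])cc(C(F)(F)F)cc12`, differs from compound 3 by cyclohexylmethyl in place of phenyl on a nitrogen on an aromatic ring. For the measured compounds named here, none of the measured steps involves a cyclohexylmethyl, so they bear on this change only in showing that swapping the group on this nitrogen among a benzyl, a 3-fluorobenzyl and a phenyl never moved the read-out off the limit. On that basis the expected step in this assay is a step that the limit leaves unreadable from compound 3 to compound 4, none beyond the scatter. Compound 4 is therefore estimated at 90 ug/mL, between 40 ug/mL and 200 ug/mL, and most likely again reported only as a limit.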

Compound 4, half-maximal inhibitory concentration: > 64 ug/mL
Compound 4: no number, only a limit (the forecaster's own chance of this, stated with the estimate: 80%); the middle value is on the limit's open side.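

Compound 4 also gives only a limit, not a number, so its steps from compound 1, compound 2 and compound 3 cannot be read: the limit of > 64 ug/mL in this assay, at which 4 of the 4 values shown sit.

The compounds shown leave open at what concentration, if any, each of these four would harm the cells.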